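Benzyl in place of cyclopentylmethyl on the shared core

The source may report more compounds than this note shows. Statements on the series, on what has been measured and on what is new or still open speak of the compounds shown alone.

Compounds measured so far:
compound 1, `Cc1nc2ccc(-c3ccc(CN4CCC[C@@H]4CO)cc3)cc2n1CCC(C)C`: 4 nM
compound 2, `Cc1nc2ccc(-c3ccc(CN4CCC[C@@H]4CO)cc3)cc2n1CC1CCCC1`: 10 nM

In an assay on cells for inhibition of sphingosine kinase 1 (Homo sapiens), read by LC-MS, with stated times of 30 min and 15 min (a lower number here means a stronger inhibitor, a higher number a weaker inhibitor), compound 2 gives 10 nM, the higher of the two numbers; its nearest neighbour is compound 1, which in this assay gives 4 nM. Within the data shown here, the one step measured, a 2.5-fold higher number from compound 1 to compound 2 (0.40 log units; beyond the scatter), is a modest loss on swapping one saturated group for another on the chain carbon bound to the aromatic nitrogen.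

Compound 3, `Cc1nc2ccc(-c3ccc(CN4CCC[C@@H]4CO)cc3)cc2n1Cc1ccccc1`, takes that position one step further: phenyl in place of cyclopentyl on a saturated chain carbon bound to an aromatic nitrogen. Among the measured compounds shown here, no measured step covers an aromatic group there, so the step from compound 1 to compound 2 is only a loose guide, suggesting that changes at this position move the number little. Compound 3 is therefore expected to give 15 nM, with a range from 4 nM to 60 nM. That estimate means a 1.5-fold higher number from compound 2 to compound 3 (0.18 log units; within the scatter), a step expected to be small or within the scatter.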

Compound 3, half-maximal inhibitory concentration: 250 nM
The estimate for compound 3 lay 17-fold (1.22 log units) below the measured number; measured number above the stated range.
By their numbers in this assay, from the lowest: compound 1; then compound 2; then compound 3.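

In this assay, the step of a 25-fold higher number from compound 2 to compound 3 (1.40 log units; beyond the scatter) for phenyl in place of cyclopentyl and the step of a 63-fold higher number from compound 1 to compound 3 (1.80 log units; beyond the scatter) for phenyl in place of isobutyl show that this position on the saturated chain carbon bound to an aromatic nitrogen does not accept every group alike. Both steps are large, whereas the earlier step of a 2.5-fold higher number from compound 1 to compound 2 (0.40 log units; beyond the scatter) between the two saturated groups was only modest, so the one aromatic ring stands well apart from both saturated groups. Nothing at hand gives a reason for this loss.

The compounds shown leave open whether the loss goes with the aromatic ring itself or with a six-membered ring, a question that cyclohexylmethyl in place of benzyl would address. They also leave open whether a fluorine or a methoxy group on the phenyl ring would change the number.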